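A few compounds are considered here, and "the series" means these few. Any claim that something is new, unique, unknown or untested is made for them only; others in the source may bear on it.

Of the compounds shown here, three built on one shared core have been measured in a physicochemical assay for lipophilicity (a lower number here means a more polar compound, a higher number a more lipophilic compound), so far. Compound 1 `CC(C)Sc1nnc(-c2c(CNC3CC3)c3ccccc3n2C)n1-c1ccccc1` gives 4.81 in this assay, and compound 2 `CC(C)Sc1nnc(-c2c(CNCCN3CCCC3)c3ccccc3n2C)n1-c1ccccc1` gives 4.83; between them the step is a number 0.02 log units higher from compound 1 to compound 2 (within the scatter). Compound 3 `COc1ccc(CNCc2c(-c3nnc(SC(C)C)n3-c3ccccc3)n(C)c3ccccc23)cc1` gives 6.27, the highest of the three numbers: it stands a number 1.44 log units higher from compound 2 to compound 3 (beyond the scatter) and a number 1.46 log units higher from compound 1 to compound 3 (beyond the scatter).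

Compound 4 `COCCNCc1c(-c2nnc(SC(C)C)n2-c2ccccc2)n(C)c2ccccc12` has not yet been measured in this assay. Its difference from compound 3 is methoxymethyl in place of 4-methoxyphenyl on a saturated chain carbon bound to an amine nitrogen. The two steps that bear on this change are a number 1.46 log units higher from compound 1 to compound 3 (beyond the scatter) and a number 1.44 log units higher from compound 2 to compound 3 (beyond the scatter), both large rises that accompanied the entry of the 4-methoxybenzyl or 4-methoxyphenyl group. Compound 4 undoes that entry and puts methoxymethyl in its place, so a large fall of comparable size is expected, a number 1.67 log units lower from compound 3 to compound 4 (beyond the scatter), bringing the number back toward those of compound 1 and compound 2. Compound 4 is therefore estimated at 4.6 in this assay, with a range from 4.1 to 5.1.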

Compound 4, partition coefficient: 4.36
Compound 4: the middle estimate sits 0.24 log units above what was measured; low and high end bracket the measured number.
By their numbers in this assay, from the lowest: compound 4; then compounds 1 and 2 (each within the scatter of the next); then compound 3.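

In this assay, methoxymethyl in place of 4-methoxyphenyl on a saturated chain carbon bound to an amine nitrogen gives a number 1.91 log units lower from compound 3 to compound 4 (beyond the scatter) and so shows that the high number of compound 3 does not survive when the ring leaves and the methoxy oxygen stays in the chain. The result also shows that this position can take the number below the earlier pair as well as above it, with a number 0.47 log units lower from compound 2 to compound 4 (beyond the scatter) and a number 0.45 log units lower from compound 1 to compound 4 (beyond the scatter) for a pair that had sat within the scatter of each other. Nothing measured here gives a cause for these steps.

Going by these compounds, it remains open whether a plain benzyl group, without the methoxy, would keep the number of compound 3. A carboxylic acid or a longer methoxyalkyl chain at this position also remains untested in the compounds shown.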